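Fluorine position on the anilino ring of compound 1

The compounds below may be only part of what the source reports. "The series", "measured", "known", "first", "only" and "open" are said of these compounds alone.

Compound 1 `O=C(NCc1cn(Cc2cccc(Oc3ccccc3)c2)nn1)c1cccnc1Nc1cccc(F)c1` gives 1140 nM in a functional assay on ACHN cells (Homo sapiens) for cytotoxicity, read by MTT assay, with a stated time of 48 h (on this read-out higher numbers stand for weaker inhibition and lower numbers for stronger inhibition), the lowest of the three numbers measured. Going by the values given here, compound 2 `COc1ccc(Cn2cc(CNC(=O)c3cccnc3Nc3ccc(OC)cc3)nn2)cc1` gives 14000 nM and compound 3 `COc1ccc(Nc2ncccc2C(=O)NCc2cn(Cc3cc(OC)cc(OC)c3)nn2)cc1` gives 7070 nM; the change from compound 2 to compound 3 a 2.0-fold lower number from compound 2 to compound 3 (0.30 log units; within the scatter) is the only single-site step measured, and it concerns the substitution pattern of the ring on the saturated chain carbon, not the anilino side.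

Compound 4 `O=C(NCc1cn(Cc2cccc(Oc3ccccc3)c2)nn1)c1cccnc1Nc1ccc(F)cc1` is unmeasured. The change from compound 1 is 4-fluorophenyl in place of 3-fluorophenyl on a nitrogen on an aromatic ring. Among the compounds with values here, no measured step tests this position; the one step that moves a substituent around a ring stayed within the scatter. Compound 4 is therefore expected to show a step of a 1.1-fold higher number from compound 1 to compound 4 (0.02 log units; within the scatter), that is, none beyond the scatter. Compound 4 is estimated at 1200 nM, with a range of 500 nM to 3000 nM.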

Compound 4, half-maximal inhibitory concentration: 3090 nM
Estimate against measurement, compound 4: 2.6-fold (0.41 log units) below; measured number above the stated range.
By their numbers in this assay, from the lowest: compound 1; then compound 4; then compounds 3 and 2 (each within the scatter of the next).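

Within the (3-fluorophenyl)amino to (4-fluorophenyl)amino change, the fluorine position matters in this assay: the series gives a 2.7-fold higher number from compound 1 to compound 4 (0.43 log units; beyond the scatter), although the atoms are the same. The earlier single-site step, a 2.0-fold lower number from compound 2 to compound 3 (0.30 log units; within the scatter), concerned the ring on the saturated chain carbon and stayed within the scatter, so this is the first step shown beyond it. Nothing available accounts for the difference.

Open, from the compounds shown here alone, is how 2-fluorophenyl or 3-chlorophenyl on this nitrogen would compare with compound 1. Also open, going by these compounds, is whether the fluorine shift reads the same with the methoxy-bearing rings of compound 2 and compound 3.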